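Trifluoromethoxy in Place of Trifluoromethyl: A Small Expected Step

The compounds below may be only part of what the source reports. "The series", "measured", "known", "first", "only" and "open" are said of these compounds alone.

Three compounds share one core and differ only in where a trifluoromethyl group sits on the aromatic ring. In an assay on cells for inhibition of protein arginine N-methyltransferase 1 (Homo sapiens), read by scintillation counting, with stated times of 15 min and 60 min, tested at 9 uM (on this read-out higher numbers stand for more inhibition at the one concentration tested (going by the name of the read-out) and lower numbers for less inhibition), compound 1 `CNCCN(C)c1nnnn1Cc1ccccc1C(F)(F)F` gives 13%. Compound 2 `CNCCN(C)c1nnnn1Cc1cccc(C(F)(F)F)c1` gives 8%, and compound 3 `CNCCN(C)c1nnnn1Cc1ccc(C(F)(F)F)cc1` gives 2%. Compound 1 holds the highest of the three numbers, although the reading of compound 2 lies within the usual scatter of it, while that of compound 3 lies beyond the scatter.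

Compound 4 `CNCCN(C)c1nnnn1Cc1ccccc1OC(F)(F)F` is not yet measured. It differs from compound 1 in one respect: trifluoromethoxy in place of trifluoromethyl on an aromatic carbon. Within the data shown here, no measured pair shows the effect of this exchange, so the expectation rests on compound 1 alone. The step of no change at the digits printed from compound 1 to compound 4 (within the scatter) is expected to stay within the scatter, with no clear direction. Compound 4 is estimated to give 13%, between 0% and 26%.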

Compound 4, a percentage reported as inhibition, at one concentration (the size of the read-out at that concentration, not a potency): 9%
Beside the measured number, compound 4's estimate is 4 percentage points above it; low and high end bracket the measured number.
By their numbers in this assay, from the lowest: compounds 3, 2, 4 and 1 (each within the scatter of the next, the first and the last beyond it).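

On an aromatic carbon ortho to a large group, trifluoromethoxy in place of trifluoromethyl gives a number 4 percentage points lower from compound 1 to compound 4 (within the scatter) in this assay, so the exchange shows no clear effect. The earlier compounds shown here only moved trifluoromethyl around the ring, whereas this pair changes the group itself while keeping its place. Nothing measured here explains the result.

Going by these compounds, whether an amine, a carboxylic acid or a nitrile at this position would move the reading beyond the scatter stays open. So does whether the same exchange would behave alike at the other ring positions.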